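Swapping the halogenated phenyl ring on a dihydrofolate reductase inhibitor

A few compounds are considered here, and "the series" means these few. Any claim that something is new, unique, unknown or untested is made for them only; others in the source may bear on it.

Measured compounds:
Compound 1 `CC(C)(C)c1ccc(OCCCON2C(N)=NC(N)=NC23CCSCC3)cc1`: 85.3%
Compound 2 `NC1=NC2(CCSCC2)N(OCCCOc2cccc(Cl)c2)C(N)=N1`: 88.3%

Of the compounds shown here, two sharing the same core have been tested in an assay on isolated protein for inhibition of Dihydrofolate reductase (Homo sapiens), read by spectrophotometry, using NADPH, with stated times of 5 s and 6 min, tested at 5 uM; on this read-out higher numbers stand for a stronger effect at the one concentration tested and lower numbers for a weaker effect. In this assay compound 1 gives 85.3%, and in the same test compound 2 gives 88.3%. Going by the values given here, compound 2 holds the higher of the two numbers, but its only neighbour, compound 1, sits so close that the gap falls within the usual scatter of repeated measurements, so the two cannot be told apart on these data. Among the compounds with values here, no step between two measured compounds differing in a single place is known, so nothing yet shows how a change at the aryl end moves the read-out.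

Compound 3 `NC1=NC2(CCSCC2)N(OCCCOc2ccc(Br)cc2)C(N)=N1` is the next compound. Compared with compound 2 it carries 4-bromophenyl in place of 3-chlorophenyl on an oxygen on a saturated carbon. Within the data shown here, the only guidance is that both measured compounds, with different substituted phenyl rings, give a similar high inhibition, so compound 3 is expected to show no step beyond the scatter, an estimated change of a number 2.3 percentage points lower from compound 2 to compound 3 (within the scatter). Compound 3 is therefore estimated at 86%, with a likely range from 74% to 95%.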

Compound 3, a percentage reported as inhibition, at one concentration (the size of the read-out at that concentration, not a potency): > 90%
Compound 3: a limit, no number; the forecaster's own chance of this, stated with the estimate: 0%; middle value at least 4 percentage points away from the limit.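

Compound 3 gives > 90% in this assay, which is a limit of the assay and not a number: the limit of > 90% in this assay, at which 1 of the 3 values shown sits. Placing 4-bromophenyl in place of 3-chlorophenyl on an oxygen on a saturated carbon gives a number at least 1.7 percentage points higher from compound 2 to compound 3 (that floor lies within the scatter) and provides the first view of a single change at this aryl end, showing that this swap keeps the read-out high. Bromo in place of tert-butyl on an aromatic carbon gives a number at least 4.7 percentage points higher from compound 1 to compound 3 (that floor lies within the scatter) and, as both figures are only floors within the scatter, neither step establishes a real gain, while the limit leaves open that the true gap is larger.

From the compounds shown here alone, from compound 2 to compound 3 the halogen and its place on the phenyl ring change together, so the effect of each alone remains unknown. Going by these compounds, it also remains open whether an amine or a carboxylic acid on the phenyl ring, or a longer chain carrying the aryloxy group, would keep inhibition this high.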